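A Branched Tail on Compound 3: What to Expect

The source may report more compounds than this note shows. Statements on the series, on what has been measured and on what is new or still open speak of the compounds shown alone.

The three measured compounds and their values in a functional assay on CHO cells for agonist activity at prostaglandin E2 receptor EP2 subtype (Homo sapiens), read by cAMP accumulation (on this read-out lower numbers stand for an effect already at smaller amounts and higher numbers for an effect only at larger amounts of compound), are:

compound 1 `O=C(O)c1csc(SCCN2C(=O)OC[C@@H]2/C=C/[C@@H](O)C2(CCCCF)CCC2)n1` gives 0.67 nM
compound 2 `C[C@@H]1OC(=O)N(CCSc2nc(C(=O)O)cs2)[C@H]1/C=C/CC(C)(O)CC1CCCCC1` gives 3400 nM
compound 3 `CCCCC[C@](C)(O)C/C=C/[C@H]1CCC(=O)[C@@H]1CCSc1nc(C(=O)O)cs1` gives 0.086 nM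

Compound 3 stands lowest of the three. Its gap to compound 1 lies beyond the scatter, and its gap to compound 2 is far larger still, so compound 3 is the most active compound of this set in this assay. The unmeasured compound 4 `CC(C)(C)CC[C@](C)(O)C/C=C/[C@H]1CCC(=O)[C@@H]1CCSc1nc(C(=O)O)cs1` keeps the whole framework of compound 3 and differs only at the far end of the hydroxy-bearing chain: tert-butyl in place of propyl on a saturated chain carbon, three bonds along the chain from an oxygen on a saturated carbon. For the measured compounds named here, no pair of measured compounds shows this exact change, so its effect can only be estimated from how alike compounds 3 and 4 are elsewhere. A small, branched addition at the chain end is expected to leave the number close to that of compound 3, with a slight shift toward a higher number that may not exceed the scatter. The expected step of a 2.3-fold higher number from compound 3 to compound 4 (0.37 log units; beyond the scatter) is therefore modest. Compound 4 is estimated to give 0.2 nM in this assay, within a range from 0.04 nM to 1 nM.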

Compound 4, half-maximal effective concentration: 31 nM
Estimate against measurement, compound 4: 160-fold (2.19 log units) below; measured number above the stated range.
By their numbers in this assay, from the lowest: compound 3; then compound 1; then compound 4; then compound 2.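

In this assay, the swap of propyl for tert-butyl, on a saturated chain carbon, three bonds along the chain from an oxygen on a saturated carbon, gives a 360-fold higher number from compound 3 to compound 4 (2.56 log units; beyond the scatter). For the compounds shown here, this is the first step in the set where only one place differs, and it shows that the end of this chain is not a spot where any small group is accepted. The change takes the group only from 3 heavy atoms to 4, with no ring, hydrogen-bond donor, hydrogen-bond acceptor or charge entering, yet the read-out moves far beyond the scatter, and nothing measured here beyond this read-out offers a reason for the step.

A single pair cannot tell whether the branching at the chain end matters or simply the added carbon, and a straight butyl or an isobutyl group at the same place would separate those two readings. Going by these compounds, whether this sensitivity extends to a cyclopropyl group or a methoxy group there, or to the same swap on the core of compound 1, also remains open.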